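Phenethyl Ether in Place of Nitrobenzyl: Cytotoxicity Outlook

The compounds below may be only part of what the source reports. "The series", "measured", "known", "first", "only" and "open" are said of these compounds alone.

Working notes on the series. Compound 2 `CCC1(Cc2ccccc2)OS(=O)(=O)C=C1OCc1ccc([N+](=O)[O-])cc1` carries a 4-nitrophenyl group on the saturated chain carbon bound to the ether oxygen. In an ADME assay on HEL cells (Homo sapiens) for cytotoxicity, with a stated time of 3 days (a higher number here means that more compound is tolerated, a lower number that less compound is tolerated), compound 2 gives < 200000 nM, which is a limit of the assay and not a number. Compound 1 `CCC1(Cc2ccccc2)OS(=O)(=O)C=C1OCc1ccc(F)cc1` is the fluoro counterpart. In this assay compound 1 gives > 50000 nM, likewise a limit. Going by the values given here, the single measured step, a step that the limit leaves unreadable from compound 1 to compound 2, cannot be read in size or direction because of the limit of < 200000 nM in this assay, at which 1 of the 2 values shown sits, and (the limit of > 50000 nM in this assay, at which 1 of the 2 values shown sits). Compound 3 `CCC1(Cc2ccccc2)OS(=O)(=O)C=C1OCCCc1ccccc1` has not yet been measured; the change from compound 2 is phenethyl in place of 4-nitrophenyl on a saturated chain carbon bound to an oxygen on an unsaturated carbon. Among the compounds with values here, no measured step bears on this change, and the one comparison in hand provides neither a direction nor a size to carry over. The expectation is therefore a step that the limit leaves unreadable from compound 2 to compound 3, a step not beyond the usual scatter, with a substantial chance that this assay again reports only a limit. For compound 3 the estimated half-maximal cytotoxic concentration is 100000 nM, expected to lie between 30000 nM and 250000 nM.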

Compound 3, half-maximal cytotoxic concentration: 133000 nM
Beside the measured number, compound 3's estimate is 1.3-fold (0.12 log units) below it; the range from low to high includes it.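

In this assay neither the step from compound 2 to compound 3 nor the step from compound 1 to compound 3 can be read, the first because of this: the limit of < 200000 nM in this assay, at which 1 of the 3 values shown sits. The second cannot be read because of this: the limit of > 50000 nM in this assay, at which 1 of the 3 values shown sits. The compounds shown leave open whether phenethyl in place of 4-nitrophenyl or 4-fluorophenyl changes the reading in this assay, and in which direction.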